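The compounds below may be only part of what the source reports. "The series", "measured", "known", "first", "only" and "open" are said of these compounds alone.

Working notes on the series. Compound 1 `COc1cc(Cl)cc(-c2nn(-c3cccc(NC(=O)Nc4cccc(C(F)(F)F)c4)c3)cc2-c2ccncc2)c1` is the reference point here. Going by the values given here, in a functional assay on RPMI-8226 cells (Homo sapiens) for inhibition, read by sulforhodamine B assay, with a stated time of 48 h, tested at 100 uM (a higher number here means a weaker effect of the compound at the concentration tested, a lower number a stronger effect), compound 1 gives -43%, the lowest of the two numbers measured so far. Among the compounds with values here, the only other measured member, compound 2 `O=C(Nc1cccc(-n2cc(-c3ccncc3)c(-c3cc(O)cc(Cl)c3)n2)c1)Nc1ccc(Cl)c(Cl)c1`, gives -27% in this assay, a number that lies higher than that of compound 1 and beyond the usual scatter; compound 2 differs from compound 1 in more than one place, so no single step between the two can be read from their values.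

Compound 3 `COc1cc(Cl)cc(-c2nn(-c3cccc(NC(=O)Nc4ccc(Cl)c(Cl)c4)c3)cc2-c2ccncc2)c1` has not yet been measured in this assay. It differs from compound 1 in one place: 3,4-dichlorophenyl in place of 3-(trifluoromethyl)phenyl on an amide-type nitrogen. The rest of the shared core is unchanged. Compound 2 carries the same 3,4-dichlorophenyl group on its urea, and its value in this assay sits above that of compound 1, but compound 2 also differs elsewhere, so that comparison offers only a weak hint.

For compound 3 a step from compound 1 of a number 8 percentage points higher from compound 1 to compound 3 (within the scatter) in this assay is expected, upward in number and modest in size, not clearly beyond the scatter. The estimate for compound 3 in this assay is -35%, with a range from -55% to -15%.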

Compound 3, a percentage reported as activity, at one concentration (the size of the read-out at that concentration, not a potency): -34%
The estimate for compound 3 lay 1 percentage points below the measured number; low and high end bracket the measured number.
By their numbers in this assay, from the lowest: compounds 1, 3 and 2 (each within the scatter of the next, the first and the last beyond it).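

In this assay, going by these compounds alone, 3,4-dichlorophenyl in place of 3-(trifluoromethyl)phenyl on an amide-type nitrogen gives a number 9 percentage points higher from compound 1 to compound 3 (within the scatter) and thus provides the first single-place reading at this position: with the rest of the core of compound 1 held constant, these two aryl groups cannot be told apart in this assay. Within the data shown here, compound 3 also provides the first single-place reading at the oxygen on the aromatic ring, where methyl in place of hydrogen gives a number 7 percentage points lower from compound 2 to compound 3 (within the scatter) with the 3,4-dichlorophenyl urea held constant, so compound 3 links each earlier compound to the series by one step that stays within the scatter. No independent measurement is available to explain either reading.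

Among these compounds, each position has so far been sampled by only one exchange, and the two aryl groups on the urea are both halogen-bearing phenyl rings, so the reach of this result remains narrow. Going by these compounds, it remains open how a carboxylic acid or an amine on that phenyl ring, a butyl chain in place of the aryl group on the amide-type nitrogen, or an ethyl group in place of methyl on the oxygen would read in this assay.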